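The compounds below may be only part of what the source reports. "The series", "measured", "known", "first", "only" and "open" are said of these compounds alone.

Within the data shown here, compound 1 `COc1ccc(/C=C/c2cc(OC)cc(OC)c2/C=C/C(=O)c2ccc(Cl)c(Cl)c2)cc1` gives 10.8 ug/mL in a functional assay on HepG2 cells (Homo sapiens) for antiproliferative activity, read by MTT assay, with a stated time of 48 h; on this read-out lower numbers stand for stronger inhibition and higher numbers for weaker inhibition; the only other measured compound, compound 2 `COc1ccc(/C=C/c2cc(OC)cc(OC)c2/C=C/C(=O)c2cccc(OC)c2)cc1`, gives 11.6 ug/mL in this assay, and that change was a 1.1-fold higher number from compound 1 to compound 2 (0.03 log units; within the scatter), so the two numbers sit together within the scatter. Compound 3 `CCN(CC)c1ccc(C(=O)/C=C/c2c(/C=C/c3ccc(OC)cc3)cc(OC)cc2OC)cc1` differs from compound 1 by 4-(diethylamino)phenyl in place of 3,4-dichlorophenyl on a carbonyl carbon. Among the measured compounds shown here, the one measured step that bears on this, an exchange of the group on the same carbonyl carbon, stayed within the scatter, so no step beyond the scatter is expected here either. The step expected is a 1.0-fold higher number from compound 1 to compound 3 (0.01 log units; within the scatter). Compound 3 is therefore estimated at 11 ug/mL, within a range from 5 ug/mL to 25 ug/mL.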

Compound 3, half-maximal inhibitory concentration: 6.3 ug/mL
For compound 3 the middle estimate is 1.7-fold (0.24 log units) above the measured one, within the range that was stated.
By their numbers in this assay, from the lowest: compounds 3, 1 and 2 (each within the scatter of the next).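

With 4-(diethylamino)phenyl on the carbonyl carbon, this position now carries a group with a nitrogen atom and more heavy atoms than 3,4-dichlorophenyl, yet this assay gives a 1.7-fold lower number from compound 1 to compound 3 (0.23 log units; within the scatter) and a 1.8-fold lower number from compound 2 to compound 3 (0.27 log units; within the scatter). Both steps lie within the scatter, so the three groups tried at this position do not separate the compounds. No available evidence accounts for this result. As far as these compounds go, it remains open whether a group of another kind on the carbonyl carbon, such as a carboxylic acid or a morpholine ring, would give a step beyond the scatter.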